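Chloro on the anilino ring of compound 1

This account rests on a few compounds, and the source may have more. Where it says the series, first, only, none or still open, it means among the compounds named here.

Measured so far:
compound 1 `CC(C)n1cnc2c(Nc3ccccc3)nc(NCOCc3ccc(C(=O)Nc4ccccc4N)cc3)nc21` – 15%
compound 2 `CC(C)n1cnc2c(Nc3ccccc3)nc(NCOCc3ccc(/C=C/C(=O)Nc4ccccc4N)cc3)nc21` – 41%
compound 3 `CC1CCN(c2nc(Cl)nc3c2ncn3Cc2ccc(/C=C/C(=O)Nc3ccccc3N)cc2)CC1` – 8.24%

In a functional assay on NCI-H460 cells (Homo sapiens) for antiproliferative activity, read by CCK-8 assay, with a stated time of 72 h, tested at 2 uM (on this read-out higher numbers stand for a stronger effect at the one concentration tested and lower numbers for a weaker effect), compound 1 gives 15%, the second highest of the three numbers. Its nearest neighbour is compound 3, with 8.24%, a difference within the scatter; compound 2 lies furthest away at 41%. Among the measured compounds shown here, the one step that connects two measured compounds in one place is a number 26 percentage points higher from compound 1 to compound 2 (beyond the scatter), a change on the linker side of the molecule.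

Compound 4 `CC(C)n1cnc2c(Nc3cccc(Cl)c3)nc(NCOCc3ccc(C(=O)Nc4ccccc4N)cc3)nc21` differs from compound 1 by chloro in place of hydrogen on an aromatic carbon. For the measured compounds named here, no measured step touches this ring, so none bears on it; the step from compound 1 to compound 2 concerns a different part of the structure and gives no guidance here. With nothing to carry over, the expectation is a step that stays within the scatter, in no fixed direction, so a number 5 percentage points higher from compound 1 to compound 4 (within the scatter) is the estimated change. Compound 4 is therefore expected to give 20% in this assay, with a range from 5% to 40%.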

Compound 4, a percentage reported as inhibition, at one concentration (the size of the read-out at that concentration, not a potency): 28.9%
Beside the measured number, compound 4's estimate is 8.9 percentage points below it, within the range that was stated.
By their numbers in this assay, from the lowest: compounds 3 and 1 (each within the scatter of the next); then compound 4; then compound 2.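

The anilino ring responds to substitution: in this assay, phenyl to 3-chlorophenyl gives a number 13.9 percentage points higher from compound 1 to compound 4 (beyond the scatter) with the rest of the molecule unchanged. Among the compounds shown here, no earlier step touched this ring, and this one shows that a single chloro on an aromatic carbon, meta to a large group, moves the number beyond the scatter. Nothing at hand explains the rise.

On these data alone, whether the rise belongs to chloro itself or to its place on the ring stays open; fluoro, methyl or methoxy on the same carbon, and chloro on another carbon of this ring, would separate the two. Also open, as far as these compounds go, is whether 3-chlorophenyl and the 2-((2-aminophenyl)carbamoyl)ethenyl group of compound 2 add up when they stand in one molecule.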